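Swapping a Styryl Arm for a Nitrophenyl Ring

This account rests on a few compounds, and the source may have more. Where it says the series, first, only, none or still open, it means among the compounds named here.

Compound 1 `C=CCOc1cc(OC)c(C(=O)/C=C/C=C/c2ccccc2)c(OCC=C)c1` carries a shared core and a 2-phenylethenyl arm. In an ADME assay on Vero cells (Chlorocebus sabaeus) for cytotoxicity, read by MTT assay (a lower number here means a stronger inhibitor, a higher number a weaker inhibitor), compound 1 stands with no number: its result is "not determined" (no result reported). Compound 2 `C=CCOc1cc(OC)c(C(=O)/C=C/c2ccncc2)c(OCC=C)c1` gives 2800 nM in this assay, while compound 3 `C=CCOc1cc(OC)c(C(=O)/C=C/c2ccc[nH]2)c(OCC=C)c1` also has only "not determined" (no result reported). Compound 4 `C=CCOc1cc(OC)c(C(=O)/C=C/c2ccc([N+](=O)[O-])cc2)c(OCC=C)c1` has not yet been measured. It differs from compound 1 in one place: 4-nitrophenyl in place of 2-phenylethenyl on a double-bonded chain carbon bound to a double-bonded chain carbon. With compound 1 lacking a value, the step to compound 4 cannot be compared with anything beyond the scatter; no change beyond it is expected. Compound 4 is estimated at 3000 nM in this assay, within a range of 800 nM to 12000 nM, because compound 2 gives 2800 nM.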

Compound 4, half-maximal inhibitory concentration: 12600 nM
Beside the measured number, compound 4's estimate is 4.2-fold (0.62 log units) below it; the measured number lies above the stated range.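

In this assay the ring at this position can change the result: 4-nitrophenyl in place of pyridin-4-yl gives a 4.5-fold higher number from compound 2 to compound 4 (0.65 log units; beyond the scatter) and makes compound 4 the weaker inhibitor of this pair. The step from compound 1 to compound 4 cannot be read, as compound 1 has no number. No available measurement explains this difference.

This single pair sets no trend for the position. On these data alone, whether an amine or a carboxylic acid on the phenyl ring would move the number up or down remains open.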